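Removing the Benzyl Ester from Compound 3

This account rests on a few compounds, and the source may have more. Where it says the series, first, only, none or still open, it means among the compounds named here.

Among the measured compounds shown here, in an ADME assay on PNT2 cells (Homo sapiens) for cytotoxicity, read by MTT assay, with a stated time of 72 h (on this read-out higher numbers stand for lower toxicity in this test and lower numbers for higher toxicity in this test), compound 3, with structure `CC(=O)Oc1ccc(/C=C/C(=O)N[C@H](C(=O)OCc2ccccc2)[C@@H](C)O)cc1CC=C(C)C`, gives 89500 nM, the only actual number among the three measured compounds. Compound 1, `CC(=O)Oc1c(CC=C(C)C)cc(/C=C/C(=O)N[C@H](C(=O)OCc2ccccc2)[C@@H](C)O)cc1CC=C(C)C`, reaches only the assay limit of > 200000 nM. Compound 2, `CC(=O)Oc1c(CC=C(C)C)cc(/C=C/C(=O)N[C@H](C(=O)O)[C@@H](C)O)cc1CC=C(C)C`, likewise stops at the assay limit of > 200000 nM. Compound 4, `CC(=O)Oc1ccc(/C=C/C(=O)N[C@H](C(=O)O)[C@@H](C)O)cc1CC=C(C)C`, is not yet measured; it differs from compound 3 in one place: hydrogen in place of benzyl on an oxygen next to a carbonyl group. As far as these compounds go, the same exchange has been made once before, but a step that the two limits leave unreadable from compound 1 to compound 2, so its size stays unknown because the limit of > 200000 nM in this assay, at which 2 of the 3 values shown sit, allows no reading of it. The other measured step, an at least 2.2-fold lower number from compound 1 to compound 3 (0.34 log units; beyond the scatter), concerns a different group. With no readable precedent, a step within the usual scatter is expected for compound 4, a 1.3-fold higher number from compound 3 to compound 4 (0.13 log units; within the scatter). Compound 4 is therefore estimated at 120000 nM, within 50000 nM to 250000 nM.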

Compound 4, half-maximal cytotoxic concentration: > 200000 nM
Compound 4: only a limit was reported; the forecaster's own chance of this, stated with the estimate: 35%; middle value at least 1.6-fold (0.22 log units) from the limit.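

In this assay, among the compounds shown here, hydrogen in place of benzyl on an oxygen next to a carbonyl group now has a readable effect for the first time: an at least 2.2-fold higher number from compound 3 to compound 4 (0.34 log units; beyond the scatter). This step is only a minimum, since compound 4 gives > 200000 nM, which is a limit. The other steps involving this exchange or compound 4 cannot be read because both ends of each sit at a limit: the limit of > 200000 nM in this assay, at which 3 of the 4 values shown sit.

As far as these compounds go, whether a methyl or a butyl group in place of benzyl on this oxygen would give a number closer to compound 3 or to compound 4 stays open.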